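Acyl chain extension on the sulfonate series

A few compounds are considered here, and "the series" means these few. Any claim that something is new, unique, unknown or untested is made for them only; others in the source may bear on it.

Compound 1 `CC(=O)Nc1ccc(S(=O)(=O)Oc2ccccc2C(C)C)cc1` is the reference point. Going by the values given here, in a functional assay on M21 cells (Homo sapiens) for antiproliferative activity, read by sulforhodamine B assay, with a stated time of 48 h (on this read-out lower numbers stand for stronger inhibition and higher numbers for weaker inhibition), compound 1 gives 21000 nM, the lowest of the two numbers so far; its only neighbour is compound 2 `CC(=O)Nc1ccc(S(=O)(=O)Oc2ccccc2I)cc1`, which in this assay gives 27000 nM. Among the compounds with values here, the one measured step, a 1.3-fold higher number from compound 1 to compound 2 (0.11 log units; within the scatter), concerns the aromatic substituent and not the amide, so its two values show only that this part of the molecule tolerates exchange without a shift beyond the scatter.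

Compound 3 `CCCCCC(=O)Nc1ccc(S(=O)(=O)Oc2ccccc2C(C)C)cc1` differs from compound 1 by butyl in place of hydrogen on a saturated chain carbon bound to a carbonyl carbon, i.e. acetamido to (pentylcarbonyl)amino. Within the data shown here, no measured step touches the acyl chain, so there is no basis in the data for a directional expectation; the step from compound 1 to compound 3 is therefore expected to be small, a 1.4-fold lower number from compound 1 to compound 3 (0.15 log units; within the scatter). Compound 3 is estimated at 15000 nM in this assay, within 5000 nM to 45000 nM.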

Compound 3, half-maximal inhibitory concentration: 6700 nM
Beside the measured number, compound 3's estimate is 2.2-fold (0.35 log units) above it; low and high end bracket the measured number.
By their numbers in this assay, from the lowest: compound 3; then compounds 1 and 2 (each within the scatter of the next).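

Going by these compounds alone, the acyl chain is the first place where a change moves the number beyond the scatter: in this assay the change from acetamido to (pentylcarbonyl)amino gives a 3.1-fold lower number from compound 1 to compound 3 (0.50 log units; beyond the scatter) as a modest step towards stronger inhibition. The exchange of isopropyl for iodo on the aromatic carbon stayed within the scatter, so this position responds where that one did not, and the added butyl is tolerated here. Nothing measured accounts for the shift.

One pair cannot show whether the number keeps falling with chain length, or whether a propyl, an octyl or a branched chain would give a similar step. It also leaves open whether the pentylcarbonyl group has the same effect on the iodo compound 2, and whether a chain carrying an amine or a carboxylic acid is accepted.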